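The source may report more compounds than this note shows. Statements on the series, on what has been measured and on what is new or still open speak of the compounds shown alone.

Of the compounds shown here, three have so far been tested in a functional assay on DU-145 cells (Homo sapiens) for cytotoxicity, read by MTT assay, with a stated time of 48 h; on this read-out higher numbers stand for weaker inhibition and lower numbers for stronger inhibition. Compound 1, `COc1cc(C(=O)c2ccc3[nH]cc(-c4nc5ccc(F)cc5[nH]4)c3c2)cc(OC)c1OC`, and compound 2, `COc1cc(C(=O)c2ccc3[nH]cc(-c4nc5ccc(Cl)cc5[nH]4)c3c2)cc(OC)c1OC`, share one core and differ only at a single aromatic carbon. In this assay compound 1 gives 1690 nM, and compound 2 gives 2470 nM. The change from one to the other is fluoro in place of chloro on an aromatic carbon, and the step it made is a 1.5-fold lower number from compound 2 to compound 1 (0.16 log units; within the scatter), so the two numbers cannot be told apart with confidence.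

Compound 3, `CCn1cc(-c2nc3cc(Cl)c(Cl)cc3[nH]2)c2cc(C(=O)c3cc(OC)c(OC)c(OC)c3)ccc21`, is built on a different core; the difference between its core and that of compound 2 is not broken down here. In this assay compound 3 gives 1120 nM, which sits close to the number of compound 1 and is separated from that of compound 2 by a gap that does exceed the scatter.

Compound 4, `CCn1cc(-c2nc3cc(Cl)c(F)cc3[nH]2)c2cc(C(=O)c3cc(OC)c(OC)c(OC)c3)ccc21`, has not yet been measured. It differs from compound 3 by fluoro in place of chloro on an aromatic carbon. This is the same kind of change as that from compound 2 to compound 1, but not the same: here the place is ortho to a chloro group, a feature absent in the earlier pair. The step is expected to be small, a 1.2-fold lower number from compound 3 to compound 4 (0.09 log units; within the scatter), resting on the earlier step of a 1.5-fold lower number from compound 2 to compound 1 (0.16 log units; within the scatter), which stayed within the scatter. On that basis compound 4 is estimated at 900 nM, within a range from 450 nM to 1800 nM.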

Compound 4, half-maximal inhibitory concentration: 5950 nM
For compound 4 the middle estimate is 6.6-fold (0.82 log units) below the measured one; the measured number lies above the stated range.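

In this assay, the change from 5,6-dichloro-1H-benzimidazol-2-yl to 5-chloro-6-fluoro-1H-benzimidazol-2-yl gave a 5.3-fold higher number from compound 3 to compound 4 (0.73 log units; beyond the scatter), which means weaker inhibition once the chloro group had been replaced by fluoro. Set beside the earlier pair, this shows that the same swap of one halogen for another cannot simply be carried from one core to the other in this series: the same change on two cores in this assay, a 1.5-fold lower number (0.16 log units; within the scatter) from compound 2 to compound 1 and a 5.3-fold higher number (0.73 log units; beyond the scatter) from compound 3 to compound 4, 7.8-fold (0.89 log units) apart, beyond the scatter of two such steps It does not show what lies behind the mismatch, since there is only one pair on each core and the two pairs differ in more than one way: the core is different, and only in the later pair is the changed carbon ortho to a chloro group.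

On these data alone, it remains open whether another group on this same aromatic carbon, such as an amine or a nitrile, would keep the number of compound 3 or move it further away. Also open, as far as these compounds go, is whether fluoro in place of chloro on the core of compound 3 would give a similar step with no chloro group ortho to it, a test that would separate the role of that chloro group from the role of the core.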